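From 4-methylphenyl to 2-iodophenyl on an amide-type nitrogen

A few compounds are considered here, and "the series" means these few. Any claim that something is new, unique, unknown or untested is made for them only; others in the source may bear on it.

compound 1 `CCCCS(=O)(=O)Oc1ccc(/C=C/C(=O)Nc2ccc(C)cc2)cc1OC` gives 26800 nM
compound 2 `CCCCOC(=O)/C=C/c1ccc(OS(=O)(=O)c2ccc(Cl)cc2)c(OC)c1` gives 14000 nM
compound 3 `COc1cc(/C=C/C(=O)Nc2cccc(C)c2)ccc1OS(=O)(=O)c1ccc(Cl)cc1` gives 73500 nM

In a toxicity assay on L02 cells (Homo sapiens) for cytotoxicity, read by MTT assay, with a stated time of 24 h (on this read-out higher numbers stand for lower toxicity in this test and lower numbers for higher toxicity in this test), compound 1 lies within the usual scatter of compound 2 and lower than compound 3, whose number is the highest of the three. The change to compound 4 `CCCCS(=O)(=O)Oc1ccc(/C=C/C(=O)Nc2ccccc2I)cc1OC` is 2-iodophenyl in place of 4-methylphenyl on an amide-type nitrogen and it puts 2-iodophenyl in place of 4-methylphenyl on an amide-type nitrogen. For the measured compounds named here, the one measured step is a 5.3-fold higher number from compound 2 to compound 3 (0.72 log units; beyond the scatter) and it replaced butoxy on a carbonyl carbon, so it bears only loosely here. Going by the values given here, no measured pair isolates the new change, which leaves the direction open. Expected in this assay is a 1.1-fold lower number from compound 1 to compound 4 (0.03 log units; within the scatter) and so no step beyond the scatter. Compound 4 is expected at 25000 nM (estimated range 9000 nM to 70000 nM).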

Compound 4, half-maximal cytotoxic concentration: 24500 nM
Compound 4: the middle estimate sits 1.0-fold (0.01 log units) above what was measured; measured number inside the range.
By their numbers in this assay, from the lowest: compounds 2, 4 and 1 (each within the scatter of the next); then compound 3.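

In this assay, 2-iodophenyl in place of 4-methylphenyl on the amide-type nitrogen gives a 1.1-fold lower number from compound 1 to compound 4 (0.04 log units; within the scatter), so the two compounds cannot be told apart on this read-out. This is the first pair shown that changes only this group, and it shows that this exchange of one ring group for another leaves the number within the scatter. No measurement shown offers a reason for this result. Still open, going by these compounds, is whether a 2-aminophenyl or 2-carboxyphenyl group on this nitrogen would also stay within the scatter of compound 1.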